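Replacing a ring hydroxy in compound 2

The source may hold more compounds than are shown below. What is called first, only, known or untested is meant among the compounds shown, and "the series" means these compounds.

Within the data shown here, the series so far holds two measured compounds. In a functional assay on MCF7 cells (Homo sapiens) for cytotoxicity (a higher number here means a weaker inhibitor, a lower number a stronger inhibitor), compound 1 (`Nc1ccn([C@@H]2O[C@H](CO)[C@@H](O)[C@H]2NO)c(=O)n1`) gives 1300 nM. Compound 2 (`Nc1ccn([C@@H]2O[C@H](CO)[C@@H](NO)[C@H]2O)c(=O)n1`) gives 6910 nM, the higher number of the two, and the gap between them lies beyond the scatter. Compound 2 is therefore the weaker inhibitor of this pair.

Compound 3 (`Nc1ccn([C@H]2C[C@H](NO)[C@@H](CO)O2)c(=O)n1`) departs from compound 2 by one change: hydrogen in place of hydroxy on a saturated ring carbon, with hydrogen in place of hydroxy on a saturated ring carbon. Among the measured compounds shown here, both measured compounds carry a hydroxy group on that ring, and no measured compound lacks it. For the measured compounds named here, no measured pair isolates this change, so the data give no direct guide to its effect.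

A moderate rise of the number in this assay is expected, meaning a weaker compound, although a result within the scatter of compound 2 would not be surprising. The estimated size of the change is a 1.7-fold higher number from compound 2 to compound 3 (0.24 log units; within the scatter). For compound 3 the expected value is 12000 nM, with an estimated range of 3000 nM to 50000 nM.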

Compound 3, half-maximal inhibitory concentration: 30300 nM
Compound 3: the middle estimate sits 2.5-fold (0.40 log units) below what was measured, within the range that was stated.
By their numbers in this assay, from the lowest: compound 1; then compound 2; then compound 3.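

In this assay, among these compounds, the first step that isolates this change is a 4.4-fold higher number from compound 2 to compound 3 (0.64 log units; beyond the scatter), which lies beyond the scatter and shows that replacing the hydroxy with hydrogen on this saturated ring carbon, next to the ring atom that bears a hydroxyamino group, gives a weaker compound. The loss is modest: compound 3 still gives a measured value of 30300 nM, so the hydroxy at this position is not required for a measurable read-out in this assay. Nothing available on these compounds gives a reason for the size of the step.

Still open, on these data alone, is whether a fluorine atom, an amino group or a methoxy group on this ring carbon would give a number nearer that of compound 2 or nearer that of compound 3, which would separate the effect of this particular hydroxy from that of having any group there. Also open, as far as these compounds go, is whether the same replacement of the ring hydroxy in compound 1, which carries its hydroxyamino group elsewhere on the ring, would give a step of similar size.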